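Pyrrolidine side-chain change on two related quinolone cores

The source may hold more compounds than are shown below. What is called first, only, known or untested is meant among the compounds shown, and "the series" means these compounds.

Compound 1 `Cc1c(F)c(N2CCC(N)C2)cc2c1c(=O)c(C(=O)O)cn2C1CC1` gives 14 ug/mL in a functional assay on V79 cells (Cricetulus griseus) for cytotoxicity, read by colony formation; a lower number here means a stronger inhibitor, a higher number a weaker inhibitor. Compound 3 `CCNCC1CCN(c2cc3c(c(C)c2F)c(=O)c(C(=O)O)cn3C2CC2)C1` carries a different group on the five-membered ring, and the change (ethylamino)methyl in place of amino on a saturated ring carbon brought a step of a 3.0-fold higher number from compound 1 to compound 3 (0.48 log units; beyond the scatter). Compound 2 `NC1CCN(c2c(F)c(F)c3c(=O)c(C(=O)O)cn(C4CC4)c3c2F)C1` has a different core; how its core differs from that of compound 1 is not broken down here. In this assay compound 2 gives 100 ug/mL, the highest of the three numbers, while compound 3 gives 42 ug/mL. Compound 4 `CCNCC1CCN(c2c(F)c(F)c3c(=O)c(C(=O)O)cn(C4CC4)c3c2F)C1` is not yet measured and arises from compound 2 by the same change, ((ethylamino)methyl in place of amino on a saturated ring carbon). Because the earlier step was a 3.0-fold higher number from compound 1 to compound 3 (0.48 log units; beyond the scatter), a step of about a 3.0-fold higher number from compound 2 to compound 4 (0.48 log units; beyond the scatter) is expected here as well. Compound 4 is therefore estimated at 300 ug/mL in this assay, with a plausible range from 120 ug/mL to 700 ug/mL.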

Compound 4, half-maximal inhibitory concentration: 46 ug/mL
The estimate for compound 4 lay 6.5-fold (0.81 log units) above the measured number, and the stated range ends above it.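

In this assay, replacing 3-aminopyrrolidin-1-yl with 3-((ethylamino)methyl)pyrrolidin-1-yl gave a 2.2-fold lower number from compound 2 to compound 4 (0.34 log units; beyond the scatter), so the number moved the opposite way on this core. The same change did not carry over from one core to the other: the same change on two cores in this assay, a 3.0-fold higher number (0.48 log units; beyond the scatter) from compound 1 to compound 3 and a 2.2-fold lower number (0.34 log units; beyond the scatter) from compound 2 to compound 4, 6.5-fold (0.81 log units) apart, beyond the scatter of two such steps. This shows that, in these two pairs, the step cannot simply be transferred between cores, but it does not show which difference between the cores is responsible or what would happen on a third core.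

The compounds shown leave open which part of the (ethylamino)methyl group matters. A plain aminomethyl group on the same ring carbon of both cores could help separate the added carbon from the ethyl group.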